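The compounds below may be only part of what the source reports. "The series", "measured", "known", "first", "only" and "open" are said of these compounds alone.

In an ADME assay on HEK293 cells (Homo sapiens) for cytotoxicity, with a stated time of 72 h (a lower number here means that less compound is needed, a higher number that more compound is needed for the effect), none of the three tested compounds has yet given a number. Compound 1 (`C=C[C@@](C)(/C=C/c1ccc(O)cc1)CC/C=C/C#N`) gives > 36600 nM, which is a limit of the assay. Compound 2 (`C=C[C@@](C)(/C=C/c1ccc(O)cc1)CC/C=C(\C)C(=O)OCC`) gives > 36600 nM, which is also a limit. Compound 3 (`C=C[C@@](C)(/C=C/c1ccc(O)c(/C=C/C#N)c1)CCC=C(C)C`) gives > 36600 nM, again a limit, and so it stands level with the other two: the limit of > 36600 nM in this assay, at which 3 of the 3 values shown sit. Compound 4 (`C=C[C@@](C)(/C=C/c1ccc(O)c(/C=C/C(=O)O)c1)CCC=C(C)C`) has carboxy in place of cyano on a double-bonded chain carbon bound to a double-bonded chain carbon. No measured step sizes this change, so the expectation rests only on compound 3 and its limit of > 36600 nM. In this assay, the estimate is a step that the limit leaves unreadable from compound 3 to compound 4, which is expected to stay within the scatter, with no direction favoured. Compound 4 is expected at 40000 nM, with an estimated range of 15000 nM to 100000 nM.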

Compound 4, half-maximal effective concentration: > 36600 nM
Compound 4 ended at the assay's limit (the forecaster's own chance of this, stated with the estimate: 70%); the middle value lies beyond the limit too.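

Compound 3 and compound 4 both end at a limit of the assay, so no step between them can be read: the limit of > 36600 nM in this assay, at which 4 of the 4 values shown sit.

The compounds shown leave open how far any of them lies beyond that limit, and whether carboxy in place of cyano makes any difference.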